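A few compounds are considered here, and "the series" means these few. Any claim that something is new, unique, unknown or untested is made for them only; others in the source may bear on it.

Compound 1, `Cc1ccc2nc(C(=O)Nc3c(F)cc(-c4cccc(F)c4)cc3F)c(C)c(O)c2c1`, gives 0.98% in a functional assay on Hep 3B2 cells (Homo sapiens) for antiproliferative activity, read by MTT assay, with a stated time of 24 h, tested at 0.02 ug/mL; a higher number here means a stronger effect of the compound at the concentration tested, a lower number a weaker effect.
Compound 2, `COc1ccc2nc(C(=O)Nc3ccc(-c4ccccc4)cc3)c(C)c(O)c2c1`, gives 0.96% in this assay.
Compound 3, `Cc1ccc2nc(C(=O)Nc3c(F)cc(-c4cccc(F)c4)cc3F)c(C)c(C(=O)O)c2c1`, gives 1.05% in this assay.

All three measured compounds share a core built around a fused two-ring system, and each carries an amide linking that core to a second aromatic part. Compound 1 and compound 3 differ in only one place: carboxy in place of hydroxy on an aromatic carbon. This single change moved the read-out by a number 0.1 percentage points higher from compound 1 to compound 3 (within the scatter), so the two compounds sit at the same level as far as this assay can tell.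

Compound 2 and compound 1 are built on cores that differ in several places at once, and the difference between the two cores is not broken down here. What their values show is that compound 2 and compound 1 stand at the same level, with compound 3 close beside them.

Compound 4, `COc1ccc2nc(C(=O)Nc3ccc(-c4ccccc4)cc3)c(C)c(C(=O)O)c2c1`, is the compound that stands to compound 2 as compound 3 stands to compound 1. The change is carboxy in place of hydroxy on an aromatic carbon, made at a place described in the same words as for the pair of compound 1 and compound 3. Since the earlier step amounted to a number 0.1 percentage points higher from compound 1 to compound 3 (within the scatter), the step from compound 2 to compound 4 is expected to be of the same small size, a number 0 percentage points higher from compound 2 to compound 4 (within the scatter). Compound 4 is therefore estimated at 1%, with a likely range from -4% to 6%.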

Compound 4, a percentage reported as inhibition, at one concentration (the size of the read-out at that concentration, not a potency): 0.05%
The estimate for compound 4 lay 1 percentage points above the measured number; the measured number falls inside the stated range.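

On the core of compound 2, putting carboxy in place of hydroxy gives a number 0.9 percentage points lower from compound 2 to compound 4 (within the scatter) in this assay, so this step is too small to count as a real effect. The same change on the core of compound 1 is also too small to count, and the two steps agree as closely as this kind of measurement can tell: the same change on two cores in this assay, a number 0.1 percentage points higher (within the scatter) from compound 1 to compound 3 and a number 0.9 percentage points lower (within the scatter) from compound 2 to compound 4, 1 percentage points apart, within the scatter of two such steps. This shows that, in these two cores, the swap leaves no effect that can be told apart from the scatter, but it does not show that the two cores truly respond alike, since a step that cannot be seen in either core gives little to compare, and a reading at a single concentration cannot reveal what would happen at other concentrations.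

The compounds shown leave open whether a different group at this place, opposite the ring nitrogen and ortho to the methyl group, such as an amine or a longer chain, would give a read-out clearly apart from those of the hydroxy and carboxy compounds. They also leave open whether the carboxy-for-hydroxy change would matter on a core, or at a concentration, where the read-out stands well clear of the scatter.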